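The compounds below may be only part of what the source reports. "The series", "measured", "known", "first", "only" and "open" are said of these compounds alone.

Measured compounds:
- Compound 1 `CC(C)c1cccc(-n2cc(COc3cccc(NC(=O)Nc4ccc(Cl)c(C(F)(F)F)c4)c3)nn2)c1`: 3250 nM
- Compound 2 `O=C(Nc1cccc(OCc2cn(-c3ccc(Cl)cc3)nn2)c1)Nc1ccc(Cl)c(C(F)(F)F)c1`: 2490 nM
- Compound 3 `O=C(Nc1cccc(OCc2cn(-c3ccc(C(F)(F)F)cc3)nn2)c1)Nc1ccc(Cl)c(C(F)(F)F)c1`: 1800 nM

All three share a core and differ only in the group attached to an aromatic nitrogen. In a functional assay on HepG2 cells (Homo sapiens) for inhibition, read by MTT assay, with a stated time of 72 h (a higher number here means a weaker inhibitor, a lower number a stronger inhibitor), compound 1 gives the highest of the three numbers, yet compound 2 and compound 3 both sit within the usual scatter of it, so no order among them can be claimed. The step of a 1.3-fold lower number from compound 1 to compound 2 (0.12 log units; within the scatter) and the step of a 1.8-fold lower number from compound 1 to compound 3 (0.26 log units; within the scatter) are both small, and the step of a 1.4-fold lower number from compound 2 to compound 3 (0.14 log units; within the scatter) is likewise within the scatter.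

Compound 4 `COc1ccccc1-n1cc(COc2cccc(NC(=O)Nc3ccc(Cl)c(C(F)(F)F)c3)c2)nn1` has not yet been measured. It differs from compound 1 at the same place as the other two: 2-methoxyphenyl in place of 3-isopropylphenyl on an aromatic nitrogen. Going by the values given here, two measured steps bear on this change, from compound 1 to compound 2 and from compound 1 to compound 3, and both stayed within the scatter. The expectation for compound 4 in this assay is therefore a step of about a 1.2-fold lower number from compound 1 to compound 4 (0.06 log units; within the scatter), that is, no change beyond the scatter. Compound 4 is estimated at 2800 nM, with a likely range from 1200 nM to 6500 nM.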

Compound 4, half-maximal inhibitory concentration: 11300 nM
Beside the measured number, compound 4's estimate is 4.0-fold (0.61 log units) below it, and the stated range ends below it.
By their numbers in this assay, from the lowest: compounds 3, 2 and 1 (each within the scatter of the next); then compound 4.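

In this assay the group on the aromatic nitrogen is not indifferent after all: 2-methoxyphenyl in place of 3-isopropylphenyl gives a 3.5-fold higher number from compound 1 to compound 4 (0.54 log units; beyond the scatter). The other two groups give the same picture, with a 4.5-fold higher number from compound 2 to compound 4 (0.66 log units; beyond the scatter) and a 6.3-fold higher number from compound 3 to compound 4 (0.80 log units; beyond the scatter), which makes compound 4 the weakest inhibitor of the four, whereas compounds 1, 2 and 3 stay within the scatter of one another. Nothing available explains this loss of activity.

Compound 4 differs from the others both in its group and in where that group sits on the phenyl ring, so the compounds shown cannot separate these two changes. They also leave open how this position responds to a phenyl ring carrying an amine or a carboxylic acid.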